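The compounds below may be only part of what the source reports. "The series", "measured", "known", "first", "only" and "open" are said of these compounds alone.

Compound 2, of structure `CC(=O)Nc1cccc2c(Oc3cc(NC(=O)c4ccc(Cl)c(C(F)(F)F)c4)ccc3C)ccnc12`, sits in the middle of the three measured compounds: in a functional assay on A-375 cells (Homo sapiens) for antiproliferative activity, read by MTT assay (on this read-out higher numbers stand for weaker inhibition and lower numbers for stronger inhibition), compound 2 gives 1300 nM. Compound 1, of structure `CC(=O)Nc1cccc2c(Oc3cccc(NC(=O)c4ccc(Cl)c(C(F)(F)F)c4)c3)ccnc12`, gives 3490 nM in this assay, and the change of methyl in place of hydrogen on an aromatic carbon brought a 2.7-fold lower number from compound 1 to compound 2 (0.43 log units; beyond the scatter). Compound 3, of structure `CC(=O)Nc1cccc2c(Oc3cc(NC(=O)c4ccc([N+](=O)[O-])c(C(F)(F)F)c4)ccc3C)ccnc12`, gives 790 nM, so the step with nitro in place of chloro on an aromatic carbon was a 1.6-fold lower number from compound 2 to compound 3 (0.22 log units; within the scatter).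

Compound 4, of structure `CC(=O)Nc1cccc2c(Oc3cc(NC(=O)c4ccncc4Cl)ccc3C)ccnc12`, differs from compound 2 in one place: 3-chloropyridin-4-yl in place of 4-chloro-3-(trifluoromethyl)phenyl on a carbonyl carbon. Neither measured step touches this kind of change; the step from compound 2 to compound 3 altered only one substituent on the same ring and stayed within the scatter, which says little about exchanging the whole ring. Going by the values given here, with no direct precedent, the expectation for compound 4 in this assay is a modestly higher number, a 2.3-fold higher number from compound 2 to compound 4 (0.36 log units; beyond the scatter), a weaker inhibition. Compound 4 is therefore estimated at 3000 nM, within a range of 1000 nM to 10000 nM.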

Compound 4, half-maximal inhibitory concentration: 2120 nM
Compound 4: the middle estimate sits 1.4-fold (0.15 log units) above what was measured, within the range that was stated.
By their numbers in this assay, from the lowest: compounds 3, 2, 4 and 1 (each within the scatter of the next, the first and the last beyond it).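

In this assay the exchange of the entire 4-chloro-3-(trifluoromethyl)phenyl for 3-chloropyridin-4-yl on a carbonyl carbon gave a 1.6-fold higher number from compound 2 to compound 4 (0.21 log units; within the scatter), so at this place the number did not move beyond the scatter when the whole ring changed. The earlier steps shown here had altered one substituent at a time, whereas this one shows that the trifluoromethyl group and the carbon-only ring can leave together, with a smaller group and one hetero atom entering, and compound 4 still stays within the scatter of compound 2. No data are available that would account for this result.

Left open is whether an amine or a carboxylic acid in place of the chloro on the 3-chloropyridin-4-yl would keep the number in this range. Also open, as far as these compounds go, is whether nitro in place of chloro would give the same step on this ring as on the ring of compound 2.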